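Pyrazoline series: removing one aryl methyl, compound 3 to 4

This account rests on a few compounds, and the source may have more. Where it says the series, first, only, none or still open, it means among the compounds named here.

Measured so far in a functional assay on HepG2 cells (Homo sapiens) for inhibition, read by CCK-8 assay, with a stated time of 48 h; a higher number here means a weaker inhibitor, a lower number a stronger inhibitor:
- compound 1 `O=C1CSC(N2N=C(c3ccc(Br)cc3)CC2c2ccc3ccccc3c2)=N1`: 18200 nM
- compound 2 `Cc1ccc(C2=NN(C3=NC(c4ccccc4)CS3)C(c3ccc4ccccc4c3)C2)cc1C`: 7370 nM
- compound 3 `Cc1ccc(C2=NN(C3=NC(c4ccccc4)CS3)C(c3cccc4ccccc34)C2)cc1C`: 7250 nM

Compound 3 gives the lowest of the three numbers, though its separation from compound 2 is within the scatter: a 1.0-fold lower number from compound 2 to compound 3 (0.01 log units; within the scatter). Only the gap to compound 1, which carries a different core, lies beyond the scatter.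

Compound 4 `Cc1ccc(C2=NN(C3=NC(c4ccccc4)CS3)C(c3cccc4ccccc34)C2)cc1` is not yet measured. It differs from compound 3 in one place: hydrogen in place of methyl on an aromatic carbon

For the measured compounds named here, no measured step in this set touches the same position, so nothing here bears on it directly. Going by the values given here, the one step available, naphthalen-1-yl for naphthalen-2-yl, left the number where it was, and the shared core of compounds 2, 3 and 4 has so far given two close values. With no evidence for a shift, the expected step for compound 4 in this assay is a 1.1-fold higher number from compound 3 to compound 4 (0.04 log units; within the scatter), meaning no change beyond the scatter. Compound 4 is therefore estimated at 8000 nM, with a range from 4000 nM to 16000 nM.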

Compound 4, half-maximal inhibitory concentration: 10400 nM
For compound 4 the middle estimate is 1.3-fold (0.11 log units) below the measured one; the measured number falls inside the stated range.
By their numbers in this assay, from the lowest: compounds 3, 2, 4 and 1 (each within the scatter of the next, the first and the last beyond it).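

In this assay, for the compounds shown here, going from 3,4-dimethylphenyl to 4-methylphenyl gives a 1.4-fold higher number from compound 3 to compound 4 (0.16 log units; within the scatter) and is the first reading on this aryl ring, since the earlier step between compound 2 and compound 3 changed only the naphthalen-2-yl to naphthalen-1-yl. With naphthalen-1-yl held in place, the methyl ortho to the other methyl group can therefore be replaced by hydrogen without moving the number beyond the scatter. The measurements shown offer no evidence on what lies behind this small step.

This single step says nothing about how the same position responds to a group other than hydrogen or methyl. On these data alone, whether a methoxy group, a chlorine, an amine or a carboxylic acid on this aromatic carbon would shift the number beyond the scatter remains open, as does the effect of also replacing the remaining methyl with hydrogen.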